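A few compounds are considered here, and "the series" means these few. Any claim that something is new, unique, unknown or untested is made for them only; others in the source may bear on it.

Working notes on the series in a functional assay on CNE-2 cells (Homo sapiens) for inhibition, read by MTT assay, with a stated time of 72 h; on this read-out lower numbers stand for stronger inhibition and higher numbers for weaker inhibition. Compound 1 `CNC(=O)CCCCCCCn1nc(-c2ccc3oc(N)nc3c2)c2c(N)ncnc21` gives 2250 nM. Compound 3 `Nc1nc2cc(-c3nn(CCCCCCCCCC(=O)NO)c4ncnc(N)c34)ccc2o1`, which carries the extended hydroxycarbamoyl chain on the same core, gives 36800 nM; the step is a 16-fold higher number from compound 1 to compound 3 (1.21 log units; beyond the scatter). Compound 2 `Nc1ncnc2c1c(-c1cnc3[nH]ccc3c1)nn2CCCC(=O)NO` returns only a limit in this assay, > 150000 nM, so no number is known for it. Compound 2 thus sits at the limit of > 150000 nM in this assay, at which 1 of the 3 values shown sits, the single limit among the three values shown.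

Compound 4 `Nc1ncnc2c1c(-c1cnc3[nH]ccc3c1)nn2CCCCCCC(=O)NO` differs from compound 2 by 3-(hydroxycarbamoyl)propyl in place of hydroxycarbamoyl on a saturated chain carbon, three bonds along the chain from an aromatic nitrogen. Going by the values given here, no measured step isolates this change: the only step on record exchanges methylcarbamoyl for a hydroxycarbamoyl chain on a different core, so it does not speak to chain length alone. What the numbers do show is that compound 3, whose hydroxycarbamoyl sits on a long chain, gives a measurable value, whereas compound 2, with the group directly on a short chain, gives only a limit. On that basis a move toward stronger inhibition is expected for compound 4 rather than none, though its size cannot be read from a measured step.

Compound 4 is expected to give about 50000 nM, within 10000 nM to 200000 nM. The expected step is an at least 3.0-fold lower number from compound 2 to compound 4 (0.47 log units; beyond the scatter).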

Compound 4, half-maximal inhibitory concentration: 19500 nM
Beside the measured number, compound 4's estimate is 2.6-fold (0.41 log units) above it, and the stated range covers the measured number.
By their numbers in this assay, from the lowest: compound 1; then compounds 4 and 3 (each within the scatter of the next). At a limit, above all of these: compound 2.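

On this core, 3-(hydroxycarbamoyl)propyl in place of hydroxycarbamoyl, on a saturated chain carbon, three bonds along the chain from an aromatic nitrogen, gives in this assay an at least 7.6-fold lower number from compound 2 to compound 4 (0.88 log units; beyond the scatter). Going by these compounds alone, the only earlier step, a 16-fold higher number from compound 1 to compound 3 (1.21 log units; beyond the scatter), exchanged methylcarbamoyl for a hydroxycarbamoyl chain, so it changed the end group; here the hydroxycarbamoyl end is kept and only the chain differs, and that change alone moves the read-out beyond the scatter. The size of this step is only a lower bound, because compound 2 is held at a limit of the assay and not at a number: the limit of > 150000 nM in this assay, at which 1 of the 4 values shown sits.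

With only two chain lengths on this core, the compounds shown do not tell whether a longer chain would continue the move or reverse it, or where along the chain it would stop. They also leave open whether the hydroxycarbamoyl end is needed on this chain at all, since a carboxylic acid, a primary amine or the methylcarbamoyl of compound 1 at that end has no value on this core.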